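The source may hold more compounds than are shown below. What is called first, only, known or untested is meant among the compounds shown, and "the series" means these compounds.

Measured so far:
compound 1, `CCOC(=O)/C=C/c1ccc(OC/C=C(\C)CCC=C(C)C)c(OC)c1`, gives 5.5% in an assay on isolated protein for inhibition of geranylgeranyl pyrophosphate synthase (Homo sapiens), tested at 100 uM; a lower number here means less inhibition, a higher number more inhibition at the concentration tested (going by the name of the read-out);
compound 2, `COc1cc(C(=O)O)ccc1OCC=C(C)C`, gives 2.4% in this assay.

Both numbers are small, and the two lie within the usual scatter of each other, so compound 2 cannot be told apart from compound 1 on these values. Compound 3, `COc1cc(C(=O)O)ccc1OC/C=C(\C)CCC=C(C)C`, has not yet been measured. It differs from compound 2 by 3-methylbut-2-en-1-yl in place of hydrogen on a saturated chain carbon bound to a double-bonded chain carbon. Compound 1 already carries such a longer chain and stays low, so no step beyond the scatter is expected in this assay. For compound 3 the expected step is a number 2.6 percentage points higher from compound 2 to compound 3 (within the scatter), and the estimate for compound 3 is 5%, between 0% and 15%.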

Compound 3, a percentage reported as inhibition, at one concentration (the size of the read-out at that concentration, not a potency): 0%
The estimate for compound 3 lay 5 percentage points above the measured number; measured number inside the range.
By their numbers in this assay, from the lowest: compounds 3, 2 and 1 (each within the scatter of the next).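

In this assay, 3-methylbut-2-en-1-yl in place of hydrogen on a saturated chain carbon bound to a double-bonded chain carbon gives a number 2.4 percentage points lower from compound 2 to compound 3 (within the scatter), so with carboxy on the ring, the longer chain cannot be told apart from the shorter one. Carboxy in place of 2-(ethoxycarbonyl)ethenyl on an aromatic carbon gives a number 5.5 percentage points lower from compound 1 to compound 3 (within the scatter), so this swap cannot be told apart either. Nothing available explains these small numbers.

From the compounds shown here alone, whether an amine or an amide in place of carboxy, or a still longer chain, would give a number beyond the scatter remains open.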